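Compound 4 and the flat step to compound 3

A few compounds are considered here, and "the series" means these few. Any claim that something is new, unique, unknown or untested is made for them only; others in the source may bear on it.

Compound 1 `COc1cc(C2CC(c3cc4ccccc4o3)=NN2C(=O)Nc2cccc(O)c2)ccc1O`: 24000000 nM
Compound 2 `COc1cc(C2CC(c3cc4ccccc4o3)=NN2C(=O)Nc2ccccc2)ccc1O`: 116000000 nM
Compound 3 `COc1cc(C2CC(c3cc4ccccc4o3)=NN2C(=O)Nc2ccc([N+](=O)[O-])cc2)ccc1O`: 113000000 nM

All three values come from a functional assay on microsomes from liver (Rattus norvegicus, strain Wistar) for inhibition, with a stated time of 15 min; a lower number here means a stronger inhibitor, a higher number a weaker inhibitor. Compound 2 shares the high end of this small range with compound 3, and the two cannot be told apart within the scatter. The only clear gaps lie elsewhere: a 4.8-fold higher number from compound 1 to compound 2 (0.68 log units; beyond the scatter), and likewise a 4.7-fold higher number from compound 1 to compound 3 (0.67 log units; beyond the scatter).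

Compound 4 `COc1cc(C2CC(c3cc4ccccc4o3)=NN2C(=O)Nc2ccc(C)cc2)ccc1O` departs from compound 2 by one change: methyl in place of hydrogen on an aromatic carbon. In words, this is methyl in place of hydrogen on an aromatic carbon, turning phenyl into 4-methylphenyl. For the measured compounds named here, no measured compound carries this methyl, so the evidence is indirect. The closest case is compound 3, a 4-nitrophenyl compound, where the new group stands in the same place and the result was flat: a 1.0-fold lower number from compound 2 to compound 3 (0.01 log units; within the scatter). The larger step to compound 2 concerns the loss of a hydroxy group, which compound 4 does not involve, so it says little here.

The expected step is none beyond the scatter: a 1.1-fold lower number from compound 2 to compound 4 (0.04 log units; within the scatter). For compound 4 the estimated value is 105000000 nM, with an expected range of 50000000 nM to 200000000 nM.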

Compound 4, half-maximal inhibitory concentration: 44000000 nM
For compound 4 the middle estimate is 2.4-fold (0.38 log units) above the measured one; the measured number lies below the stated range.
By their numbers in this assay, from the lowest: compounds 1 and 4 (each within the scatter of the next); then compounds 3 and 2 (each within the scatter of the next).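

In this assay the group para to a large group on this phenyl ring is not indifferent, since methyl in place of hydrogen gives a 2.6-fold lower number from compound 2 to compound 4 (0.42 log units; beyond the scatter) and methyl in place of nitro at the same place gives a 2.6-fold lower number from compound 3 to compound 4 (0.41 log units; beyond the scatter); the earlier pair of hydrogen and nitro had shown no such separation. Until now only compound 1, with its 3-hydroxyphenyl, stood clearly apart from compound 2 and compound 3, but the 4-methylphenyl of compound 4 joins it at that end of the range, with a 1.8-fold higher number from compound 1 to compound 4 (0.26 log units; within the scatter) as the step between them. Nothing shown gives a reason for these steps, and no separate measurement bears on them.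

As far as these compounds go, it remains open whether the shift belongs to methyl alone or would also appear with an ethyl chain, a methoxy group or an amine at the same place. From the compounds shown here alone, it is equally open whether methyl at the place the hydroxy group holds in compound 1 would match 4-methylphenyl, and whether a hydroxy group para to a large group would do the same.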